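The compounds below may be only part of what the source reports. "The series", "measured", "known", "first", "only" and "open" are said of these compounds alone.

In an ADME assay on the whole organism for cytotoxicity, with Artemia salina as the target, with a stated time of 24 h (a higher number here means that more compound is needed for the effect, a lower number that less compound is needed), compound 2 `COc1ccc(/C=C/C(=O)c2ccccc2NC(=O)NS(=O)(=O)c2ccc(C)cc2)cc1` gives 28.1 ug/mL and compound 1 `Cc1ccc(S(=O)(=O)NC(=O)Nc2ccccc2C(=O)/C=C/c2ccc(N(C)C)cc2)cc1` gives 38.1 ug/mL; the two stand together, since the step of a 1.4-fold lower number from compound 1 to compound 2 (0.13 log units; within the scatter) is within the scatter. Compound 3 `Cc1ccc(S(=O)(=O)NC(=O)Nc2ccccc2C(=O)/C=C/c2cccc(O)c2)cc1` differs from compound 2 by 3-hydroxyphenyl in place of 4-methoxyphenyl on a double-bonded chain carbon bound to a double-bonded chain carbon. Among the compounds with values here, the only measured step that bears on this, a 1.4-fold lower number from compound 1 to compound 2 (0.13 log units; within the scatter), also alters the group on that same aryl ring and stayed within the scatter, so no step beyond the scatter is expected here in this assay either. Compound 3 is accordingly estimated at 30 ug/mL, with a range from 12 ug/mL to 75 ug/mL. The expected step is a 1.1-fold higher number from compound 2 to compound 3 (0.03 log units; within the scatter).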

Compound 3, concentration for half-maximal effect: 39.3 ug/mL
Estimate against measurement, compound 3: 1.3-fold (0.12 log units) below, and the stated range covers the measured number.
By their numbers in this assay, from the lowest: compounds 2, 1 and 3 (each within the scatter of the next).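

In this assay the step of a 1.4-fold higher number from compound 2 to compound 3 (0.15 log units; within the scatter) and the step of a 1.0-fold higher number from compound 1 to compound 3 (0.01 log units; within the scatter) both stay within the scatter. At this place, on a double-bonded chain carbon bound to a double-bonded chain carbon, 3-hydroxyphenyl with its hydrogen-bond donor therefore stands together with both 4-methoxyphenyl and 4-(dimethylamino)phenyl. No measurement at hand speaks to why these numbers stand together.

Still open, going by these compounds, is whether a carboxylic acid or a primary amine on this phenyl ring would give a step beyond the scatter. Also open, on these data alone, is whether a change elsewhere on the shared core would do so.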